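This account rests on a few compounds, and the source may have more. Where it says the series, first, only, none or still open, it means among the compounds named here.

Measured so far in a functional assay on HT-1080 cells (Homo sapiens) for antiproliferative activity, read by MTT assay, with a stated time of 72 h; on this read-out lower numbers stand for stronger inhibition and higher numbers for weaker inhibition:
compound 1 `COc1ccc(-c2sc(C(=O)O)cc2-c2cc(OC)c(OC)c(OC)c2)cc1[N+](=O)[O-]` gives 37200 nM
compound 2 `COc1cc(-c2cc(C(=O)O)sc2-c2ccc3ccccc3c2)cc(OC)c1OC` gives 13400 nM

Compound 2 has the lower of the two numbers, and its gap to compound 1 lies beyond the scatter. Compound 3 `COc1ccc(-c2sc(C(=O)O)cc2-c2cc(OC)c(OC)c(OC)c2)cc1O` is not yet measured. It differs from compound 2 on the aromatic carbon next to the ring sulfur, with 3-hydroxy-4-methoxyphenyl in place of naphthalen-2-yl (3-hydroxy-4-methoxyphenyl in place of naphthalen-2-yl on an aromatic carbon). No measured step sizes this change. The estimated 1.1-fold lower number from compound 2 to compound 3 (0.05 log units; within the scatter) is expected to stay within the scatter, with no clear direction in this assay. Compound 3 is estimated at 12000 nM, with 3500 nM to 40000 nM as its expected range.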

Compound 3, half-maximal inhibitory concentration: 7510 nM
Compound 3: middle estimate off by 1.6-fold (0.20 log units), on the high side, and the stated range covers the measured number.
By their numbers in this assay, from the lowest: compounds 3 and 2 (each within the scatter of the next); then compound 1.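

In this assay, 3-hydroxy-4-methoxyphenyl in place of naphthalen-2-yl on the aromatic carbon next to the ring sulfur gives a 1.8-fold lower number from compound 2 to compound 3 (0.25 log units; within the scatter), so this position takes either group without the two being told apart, despite their different hydrogen-bond donor and acceptor counts. Within the aryl group at this position, hydroxy in place of nitro gives a 5.0-fold lower number from compound 1 to compound 3 (0.69 log units; beyond the scatter), so the substituent there does register in this read-out. From the compounds shown here alone, whether an amine in place of the hydroxy would give a similar number stays open. Nothing available explains either step.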